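Replacing Ethyl with 4-Methylpiperazin-1-yl in Compound 1

The compounds below may be only part of what the source reports. "The series", "measured", "known", "first", "only" and "open" are said of these compounds alone.

Compound 1 `CCc1ccc(NC(=O)C2CCN(C/C=C/c3ccccc3)CC2)cc1` gives 20000 nM in a functional assay on MCF7 cells (Homo sapiens) for inhibition, read by MTT assay, with a stated time of 72 h; a higher number here means a weaker inhibitor, a lower number a stronger inhibitor
Compound 2 `O=C(Nc1cccc(Cl)c1)C1CCN(C/C=C/c2ccccc2)CC1` gives 16100 nM in this assay
Compound 3 `O=C(Nc1cccc(Br)c1)C1CCN(C/C=C/c2ccccc2)CC1` gives 11500 nM in this assay

In this assay compound 1 lies within the scatter of compound 2 and of compound 3, so these three values do not separate the compounds. Compound 4 `CN1CCN(c2ccc(NC(=O)C3CCN(C/C=C/c4ccccc4)CC3)cc2)CC1` keeps the core of compound 1 and carries 4-methylpiperazin-1-yl in place of ethyl on an aromatic carbon, para to a large group (4-methylpiperazin-1-yl in place of ethyl on an aromatic carbon). Two measured steps change the group on the amide-type nitrogen: a 1.2-fold lower number from compound 1 to compound 2 (0.09 log units; within the scatter) and a 1.7-fold lower number from compound 1 to compound 3 (0.24 log units; within the scatter) are both small. The remaining step, a 1.4-fold lower number from compound 2 to compound 3 (0.15 log units; within the scatter), is small as well. None of these steps introduces 4-methylpiperazin-1-yl, so they offer only indirect guidance and the range must stay wide. No change beyond the scatter is therefore expected. The expected step is a 1.7-fold lower number from compound 1 to compound 4 (0.22 log units; within the scatter) in this assay with considerable uncertainty. For compound 4 the estimated value is 12000 nM in this assay with an expected range from 4000 nM to 30000 nM for repeated measurements.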

Compound 4, half-maximal inhibitory concentration: 44000 nM
Estimate against measurement, compound 4: 3.7-fold (0.56 log units) below; measured number above the stated range.
By their numbers in this assay, from the lowest: compounds 3, 2 and 1 (each within the scatter of the next); then compound 4.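

In this assay, putting 4-methylpiperazin-1-yl in place of ethyl on an aromatic carbon, para to a large group, gives a 2.2-fold higher number from compound 1 to compound 4 (0.34 log units; beyond the scatter). Among these compounds, this is the first step to lie beyond the scatter, as all the earlier steps stayed within it, so this position does respond to a change of group, and here the change gives a weaker inhibitor, though only modestly. Nothing available here accounts for the shift.

Going by these compounds, it remains open whether the higher number goes with the six-membered non-aromatic ring itself or with its nitrogens. A piperidin-1-yl or morpholin-4-yl group at the same place would bear on that question, and a longer alkyl chain such as butyl would show how this position responds without any ring.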